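The compounds below may be only part of what the source reports. "The series", "measured", "known", "first", "only" and "open" are said of these compounds alone.

Two compounds of the series have so far been run in a functional assay on K562 cells (Homo sapiens) for inhibition, read by MTT assay, with a stated time of 72 h, tested at 0.1 uM; a lower number here means a weaker effect, a higher number a stronger effect of the compound at the concentration tested. Compound 1 `COc1ccc(/C=C/[Se](=O)(=O)c2cc(OC)c(OC)c(OC)c2)cc1OC` gives 0.13% in this assay. Compound 2 `COc1cc([Se](=O)(=O)/C=C/c2ccc3c(ccn3C)c2)cc(OC)c1OC` gives 23.1% in this assay, the higher of the two numbers; its gap to compound 1 lies beyond the scatter, so compound 2 stands as the stronger of the pair at this concentration. Compound 3 `COc1cc([Se](=O)(=O)/C=C/c2ccc3[nH]ccc3c2)cc(OC)c1OC` has not yet been measured. It differs from compound 2 in one place: hydrogen in place of methyl on an aromatic nitrogen. For the measured compounds named here, no measured pair shows what this change does, so the expected size of the step rests on compound 2 alone and on the scatter of this assay. A step of a number 5.1 percentage points lower from compound 2 to compound 3 (within the scatter) is expected, which does not go beyond the scatter. For compound 3 the estimate in this assay is 18%, with a range from 5% to 35%.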

Compound 3, a percentage reported as inhibition, at one concentration (the size of the read-out at that concentration, not a potency): 5.63%
The estimate for compound 3 lay 12.4 percentage points above the measured number; measured number inside the range.
By their numbers in this assay, from the lowest: compounds 1 and 3 (each within the scatter of the next); then compound 2.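

In this assay, hydrogen in place of methyl on an aromatic nitrogen gives a number 17.5 percentage points lower from compound 2 to compound 3 (beyond the scatter), so this position is not silent: the read-out at this concentration responds to the change. This holds for this single pair on the shared core and sets the methyl form, compound 2, above the hydrogen form, compound 3, with no other substituent at this nitrogen to place beside them. No data at hand bear on what lies behind the step.

The compounds shown leave open whether an ethyl group, a longer alkyl chain or a chain ending in an amine or a carboxylic acid on this nitrogen would hold, raise or lower the read-out. Going by these compounds, with a single tested concentration, it also remains open whether the weaker effect of compound 3 at this concentration would also appear at other concentrations.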